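Indol-2-yl for methoxyphenyl on the ring amide nitrogen

This account rests on a few compounds, and the source may have more. Where it says the series, first, only, none or still open, it means among the compounds named here.

Measured so far in a functional assay on HCT-116 cells (Homo sapiens) for inhibition, read by sulforhodamine B assay, with a stated time of 48 h; a higher number here means a weaker inhibitor, a lower number a stronger inhibitor:
- compound 1 `CO[C@@H]1CC=C2NN(c3cc4ccccc4[nH]3)C(=O)C[C@]2(c2ccncc2)O1`: 4350 nM
- compound 2 `COc1ccc(N2NC3=CC[C@@H](OC)O[C@@]3(c3ccccc3)CC2=O)cc1`: 11300 nM
- compound 3 `CO[C@@H]1CC=C2NN(c3ccc(Cl)cc3)C(=O)C[C@]2(C)O1`: 35700 nM

Compound 2 stands second highest of the three numbers. Its nearest neighbour is compound 1, whose number is lower by a gap beyond the usual scatter; compound 3 is furthest, with a higher number, again beyond the scatter. For the measured compounds named here, no pair of these three differs in only one place, so no single-change step can be read off directly; compound 1 and compound 2 differ both on the ring amide nitrogen and on the carbon bearing the aryl group.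

The unmeasured compound 4 `CO[C@@H]1CC=C2NN(c3cc4ccccc4[nH]3)C(=O)C[C@]2(c2ccccc2)O1` keeps the phenyl group of compound 2 and changes only the group on the ring amide nitrogen: 1H-indol-2-yl in place of 4-methoxyphenyl on an amide-type nitrogen in a ring.

Compound 1, which already carries the 1H-indol-2-yl group, gives the lowest number of the series in this assay, and compound 4 now shares that group. The step is therefore expected to go down, by an amount close to or somewhat beyond the scatter, as compound 1 suggests with 4350 nM; the estimated step is a 2.1-fold lower number from compound 2 to compound 4 (0.31 log units; beyond the scatter). For compound 4 the estimate in this assay is 5500 nM, with a range from 2000 nM to 15000 nM.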

Compound 4, half-maximal inhibitory concentration: 8200 nM
For compound 4 the middle estimate is 1.5-fold (0.17 log units) below the measured one, and the stated range covers the measured number.
By their numbers in this assay, from the lowest: compounds 1, 4 and 2 (each within the scatter of the next, the first and the last beyond it); then compound 3.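

On the ring amide nitrogen, 1H-indol-2-yl in place of 4-methoxyphenyl with phenyl held on the saturated ring carbon gives a 1.4-fold lower number from compound 2 to compound 4 (0.14 log units; within the scatter) in this assay, so this exchange of one aromatic group for another does not separate the two groups in this assay. On the saturated ring carbon, phenyl in place of pyridin-4-yl with 1H-indol-2-yl held on the nitrogen gives a 1.9-fold higher number from compound 1 to compound 4 (0.28 log units; within the scatter), and the ring nitrogen of pyridin-4-yl is therefore not shown to matter here. For the compounds shown here, these are the first single-change readings, and neither change alone moves the number beyond the scatter. Nothing on hand bears on why either step is this small.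

Open, from the compounds shown here alone, is whether a piperidin-4-yl group on the saturated ring carbon, or a carboxylic acid on the aryl group of the ring amide nitrogen, would give a step beyond the scatter. The methoxy group on the shared core also stays the same in all four compounds, so a hydroxyl or ethoxy group in its place remains an open comparison.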